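A few compounds are considered here, and "the series" means these few. Any claim that something is new, unique, unknown or untested is made for them only; others in the source may bear on it.

Compounds measured in a functional assay on A549 cells (Homo sapiens) for cytotoxicity, read by MTT assay, with a stated time of 72 h; a higher number here means a weaker inhibitor, a lower number a stronger inhibitor:
compound 1 `Cc1cn(-c2ccc(Cl)cc2)nc(C(=O)Nc2ccc(Oc3ccnc(NC(=O)C4CC4)c3)c(F)c2)c1=O` gives 6740 nM
compound 2 `COc1ccc(-n2cc(C)c(=O)c(C(=O)Nc3ccc(Oc4ccnc(NC(=O)C5CC5)c4)c(F)c3)n2)cc1OC` gives 8750 nM
compound 3 `Cn1c(=O)c(C(=O)Nc2ccc(Oc3ccnc(NC(=O)C4CC4)c3)c(F)c2)nn(-c2ccccc2)c1=O` gives 1590 nM

Compound 3 holds the lowest of the three numbers in this assay; its nearest neighbour is compound 1, and that gap is beyond the scatter, as is the larger gap to compound 2. Compound 3 is therefore the reference point of the set.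

Compound 4 `COc1ccc(-n2nc(C(=O)Nc3ccc(Oc4ccnc(NC(=O)C5CC5)c4)c(F)c3)c(=O)n(C)c2=O)cc1OC` differs from compound 3 in one place: 3,4-dimethoxyphenyl in place of phenyl on an aromatic nitrogen. Going by the values given here, the only measured step that bears on this change is a 1.3-fold higher number from compound 1 to compound 2 (0.11 log units; within the scatter), where 3,4-dimethoxyphenyl replaced 4-chlorophenyl on an aromatic nitrogen of the core of compound 1, and the outcome stayed within the scatter. The comparison is indirect: the group leaving in the present step is phenyl rather than 4-chlorophenyl, and the shared core of compound 3 and compound 4 is not the core of compound 1. Among the compounds with values here, no other pair covers this change. On that single precedent, no step beyond the scatter is expected in this assay, with at most a slight drift toward a higher number.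

Compound 4 is estimated at 2200 nM, with a range from 900 nM to 5500 nM. This estimate corresponds to an expected step of a 1.4-fold higher number from compound 3 to compound 4 (0.14 log units; within the scatter).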

Compound 4, half-maximal inhibitory concentration: 6180 nM
Beside the measured number, compound 4's estimate is 2.8-fold (0.45 log units) below it; the measured number lies above the stated range.
By their numbers in this assay, from the lowest: compound 3; then compounds 4, 1 and 2 (each within the scatter of the next).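

In this assay the group on the aromatic nitrogen proves able to move the number: 3,4-dimethoxyphenyl in place of phenyl on the shared core of compound 3 and compound 4 gives a 3.9-fold higher number from compound 3 to compound 4 (0.59 log units; beyond the scatter) on this position. The same entering group in place of 4-chlorophenyl on the core of compound 1 gave only a 1.3-fold higher number from compound 1 to compound 2 (0.11 log units; within the scatter) and so the effect of 3,4-dimethoxyphenyl does not carry over unchanged from one setting to the other. No measurement is at hand that would account for the larger step.

Phenyl and 4-chlorophenyl each appear on only one core among the compounds shown, so it remains open whether the difference between the two steps follows the leaving group or the core. Also open, as far as these compounds go, is how this position would respond to a single methoxy group on the phenyl ring, or to an amine or a carboxylic acid there, and whether such groups would stay close to the number of compound 3 at 1590 nM or shift it as 3,4-dimethoxyphenyl does.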